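The compounds below may be only part of what the source reports. "The series", "measured", "known", "first", "only" and "open" are said of these compounds alone.

Measured compounds:
- compound 1, `CC1(C)[C@H]2CC[C@]1(C)[C@H](OC(=O)CN1CCCCC1)C2`: 141000 nM
- compound 2, `CC1CCN(CCCCC(=O)O[C@@H]2C[C@@H]3CC[C@@]2(C)C3(C)C)CC1`: 73000 nM

In an ADME assay on HEK-293T cells (Homo sapiens) for cytotoxicity, read by MTT assay, with a stated time of 48 h (a lower number here means that less compound is tolerated, a higher number that more compound is tolerated), compound 1 gives 141000 nM. The only other measured compound, compound 2, gives 73000 nM in this assay; the two numbers lie within the scatter of each other, so nothing separates them, and compound 1 stands level with compound 2 on the numbers shown. Among the measured compounds shown here, no step between measured compounds is available that would show how a single change moves the result.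

Compound 3, `CCN(CC)CCC(=O)O[C@@H]1C[C@@H]2CC[C@@]1(C)C2(C)C`, is not yet measured. It differs from compound 1 in one place: (diethylamino)methyl in place of piperidin-1-yl on a saturated chain carbon bound to a carbonyl carbon. The ring opens into a chain, while the count of heavy atoms and the single acceptor stay the same. For the measured compounds named here, with no comparable step to draw on, the expectation is a step of a 1.2-fold lower number from compound 1 to compound 3 (0.07 log units; within the scatter) that stays within the scatter, in no settled direction. Compound 3 is therefore estimated at 120000 nM in this assay, with a range from 50000 nM to 280000 nM.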

Compound 3, half-maximal cytotoxic concentration: 327000 nM
Compound 3: middle estimate off by 2.7-fold (0.44 log units), on the low side; measured number outside the range, above it.
By their numbers in this assay, from the lowest: compounds 2 and 1 (each within the scatter of the next); then compound 3.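

In this assay, putting (diethylamino)methyl in place of piperidin-1-yl on a saturated chain carbon bound to a carbonyl carbon gives a 2.3-fold higher number from compound 1 to compound 3 (0.37 log units; beyond the scatter). This first single-change comparison shows that the group at this position can shift the result even when the core stays the same and the heavy atoms and hydrogen-bond acceptors count the same on both sides, with the open-chain amine tolerated at higher concentrations than the ring. Nothing shown explains why the open chain and the ring differ.

As far as these compounds go, whether the same rise would appear with a smaller amine such as dimethylamino, or with a morpholine ring in place of the piperidine ring, remains open. One step also cannot show whether the change would have the same effect on a longer chain.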